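A few compounds are considered here, and "the series" means these few. Any claim that something is new, unique, unknown or untested is made for them only; others in the source may bear on it.

Working notes on the series, read in a functional assay on SK-BR-3 cells (Homo sapiens) for antiproliferative activity, read by XTT assay, with a stated time of 72 h; a higher number here means a weaker inhibitor, a lower number a stronger inhibitor. Compound 1 `COc1ccc(-c2cc3ccccc3nc2/C=C/C(=O)c2ccccc2)cc1` gives 700 nM and compound 2 `COc1ccc(-c2cc3ccccc3nc2/C=C/C(=O)c2ccc(F)cc2)cc1` gives 810 nM, a pair separated only by a 1.2-fold higher number from compound 1 to compound 2 (0.06 log units; within the scatter). Compound 3 `COc1ccc(-c2cc3ccccc3nc2/C=C/C(=O)c2ccc(OC)cc2OC)cc1` gives 2260 nM. Compound 2 therefore stands level with compound 1, and its distance to the remaining number is a 2.8-fold higher number from compound 2 to compound 3 (0.45 log units; beyond the scatter).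

Compound 4 `COc1ccc(-c2cc3ccccc3nc2/C=C/C(=O)c2c(OC)cccc2OC)cc1` has not yet been measured. The change to follow is 2,6-dimethoxyphenyl in place of 4-fluorophenyl on a carbonyl carbon. The nearest evidence is compound 3, which also carries a dimethoxyphenyl group, in its case 2,4-dimethoxyphenyl. That group gave the modest step already noted from compound 2, and the similarly modest a 3.2-fold higher number from compound 1 to compound 3 (0.51 log units; beyond the scatter). Within the data shown here, no measured compound carries the 2,6-dimethoxyphenyl group, so this transfer remains uncertain. A modest step toward a higher number in this assay is expected on the strength of these two steps, although a step within the scatter cannot be excluded. The expected step is a 2.5-fold higher number from compound 2 to compound 4 (0.39 log units; beyond the scatter). For compound 4 the estimated value is 2000 nM, with an expected range from 800 nM to 5000 nM.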

Compound 4, half-maximal inhibitory concentration: 3830 nM
The estimate for compound 4 lay 1.9-fold (0.28 log units) below the measured number; the range from low to high includes it.
By their numbers in this assay, from the lowest: compounds 1 and 2 (each within the scatter of the next); then compounds 3 and 4 (each within the scatter of the next).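

In this assay the 2,6-dimethoxyphenyl group on the carbonyl carbon gives a 4.7-fold higher number from compound 2 to compound 4 (0.67 log units; beyond the scatter) and a 5.5-fold higher number from compound 1 to compound 4 (0.74 log units; beyond the scatter), so a second dimethoxyphenyl arrangement now stands apart from both the phenyl and the 4-fluorophenyl compounds, as compound 3 already did. Against the 2,4-dimethoxyphenyl group the change gives a 1.7-fold higher number from compound 3 to compound 4 (0.23 log units; within the scatter), so the two arrangements cannot be told apart here, and the higher numbers in this set go with both dimethoxyphenyl compounds rather than with one arrangement alone. Nothing measured here accounts for this step through any property of the group.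

The compounds shown leave open whether a single methoxy group on this phenyl ring would already give a step of this kind, or whether both methoxy groups are needed. Also open, as far as these compounds go, is how an amine or a carboxylic acid on the same ring would read, and whether the dimethoxyphenyl step holds when the shared core is changed.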